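The compounds below may be only part of what the source reports. "The series", "measured", "known", "first", "only" and "open" are said of these compounds alone.

Working notes on the series. Compound 1 `COC(=O)c1c(C)[n+]([O-])c2ccc(C)cc2[n+]1[O-]` and compound 2 `CCc1c(C(=O)OC)[n+]([O-])c2cc(C)c(C)cc2[n+]1[O-]` share a core; compound 3 `CCc1c(C(=O)OC)[n+]([O-])c2cc(C)ccc2[n+]1[O-]` is not yet measured. In an ADME assay on Vero cells (Chlorocebus sabaeus) for cytotoxicity (on this read-out higher numbers stand for weaker inhibition and lower numbers for stronger inhibition), compound 1 returns > 62.5 ug/mL, a limit of the assay rather than a number. In this assay compound 2 likewise returns > 62.5 ug/mL, again only a limit. Within the data shown here, compound 2 thus stands where every value so far stands: the limit of > 62.5 ug/mL in this assay, at which 2 of the 2 values shown sit, so nothing orders compound 1 against compound 2. The change from compound 2 to compound 3 is hydrogen in place of methyl on an aromatic carbon. Among the measured compounds shown here, no measured step of this kind exists, and the two results separate no compound from another, so in this assay the step is expected to be none beyond the scatter, a step that the limit leaves unreadable from compound 2 to compound 3. Compound 3 is accordingly expected to give 80 ug/mL, within 40 ug/mL to 200 ug/mL, most likely reported again only as a limit.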

Compound 3, half-maximal inhibitory concentration: > 62.5 ug/mL
Compound 3: no number, only a limit (the forecaster's own chance of this, stated with the estimate: 75%); the middle value is on the limit's open side.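

No step can be read from compound 3 against compound 1 or compound 2, since every result in this assay is a limit: the limit of > 62.5 ug/mL in this assay, at which 3 of the 3 values shown sit.

The compounds shown leave open how compound 1, compound 2 and compound 3 order in this assay, and whether any single change on the shared core alters the read-out.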